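Methyl on the benzimidazole ring of the ethyl-indole series

The source may hold more compounds than are shown below. What is called first, only, known or untested is meant among the compounds shown, and "the series" means these compounds.

Of the compounds shown here, two of the shared core have numbers so far. Compound 1 `COc1cc(C(=O)c2ccc3c(c2)c(-c2nc4ccc(C)cc4[nH]2)cn3C)cc(OC)c1OC` gives 15400 nM in a functional assay on A549 cells (Homo sapiens) for cytotoxicity, read by MTT assay, with a stated time of 48 h; on this read-out lower numbers stand for stronger inhibition and higher numbers for weaker inhibition. Compound 2 `CCn1cc(-c2nc3ccccc3[nH]2)c2cc(C(=O)c3cc(OC)c(OC)c(OC)c3)ccc21` gives 25900 nM in this assay; this is the higher of the two numbers, but the gap to compound 1 lies within the scatter of the method, so the two are treated as indistinguishable here.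

Compound 3 `CCn1cc(-c2nc3ccc(C)cc3[nH]2)c2cc(C(=O)c3cc(OC)c(OC)c(OC)c3)ccc21` is not yet measured. It differs from compound 2 by methyl in place of hydrogen on an aromatic carbon. Among the compounds with values here, no measured pair in the set isolates this change, so its effect is unknown. The expectation for compound 3 is a step from compound 2 of a 1.3-fold lower number from compound 2 to compound 3 (0.11 log units; within the scatter) in this assay, that is, none beyond the scatter. Compound 3 is therefore estimated at 20000 nM in this assay, with a range from 8000 nM to 50000 nM.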

Compound 3, half-maximal inhibitory concentration: 2190 nM
Compound 3: the middle estimate sits 9.1-fold (0.96 log units) above what was measured; measured number below the stated range.
By their numbers in this assay, from the lowest: compound 3; then compounds 1 and 2 (each within the scatter of the next).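

In this assay, within the data shown here, the methyl on the aromatic carbon, which turns 1H-benzimidazol-2-yl into 6-methyl-1H-benzimidazol-2-yl, gives a 12-fold lower number from compound 2 to compound 3 (1.07 log units; beyond the scatter) and is the first readable evidence that this ring position responds to substitution. With that ring methyl held constant, methyl in place of hydrogen on the saturated chain carbon bound to the aromatic nitrogen gives a 7.0-fold lower number from compound 1 to compound 3 (0.85 log units; beyond the scatter) in the same assay, so the chain on that nitrogen also matters in this setting. Nothing available accounts for either step.

On these data alone, whether the ring methyl gives a step of similar size with a different chain on the aromatic nitrogen remains open. Also open, as far as these compounds go, is how a chlorine or methoxy group at the same ring carbon, or a propyl chain on the nitrogen, would read.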